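Compound 3: one methoxy step in a thin series

A few compounds are considered here, and "the series" means these few. Any claim that something is new, unique, unknown or untested is made for them only; others in the source may bear on it.

In an ADME assay on WS1 cells (Homo sapiens) for inhibition, with a stated time of 48 h (a lower number here means a stronger inhibitor, a higher number a weaker inhibitor), compound 1 (`COc1cc2oc(/C=C/[S+](C)[O-])cc(=O)c2cc1OC`) gives > 10000 nM, which is a limit of the assay and not a number. Going by the values given here, compound 2 (`C[S+]([O-])/C=C/c1cc(=O)c2ccccc2o1`) gives 9000 nM, the only true number so far, so it cannot yet be ranked against a second measured value. Compound 3 (`COc1ccc2oc(/C=C/[S+](C)[O-])cc(=O)c2c1`) is compound 2 with methoxy in place of hydrogen on an aromatic carbon. Among the compounds with values here, the series holds no measured step to show what such a change does in this assay. With compound 2 at 9000 nM as the only anchor, no change beyond the scatter is expected, and no direction is favoured. The estimated move is a 1.1-fold higher number from compound 2 to compound 3 (0.05 log units; within the scatter). For compound 3 the expected value is 10000 nM, with an estimated range of 4500 nM to 20000 nM.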

Compound 3, half-maximal inhibitory concentration: 6000 nM
Compound 3: the middle estimate sits 1.7-fold (0.22 log units) above what was measured, and the stated range covers the measured number.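

In this assay, going by these compounds alone, the first readable step at this position, an aromatic carbon meta to a fused ring and para to a fused ring, is a 1.5-fold lower number from compound 2 to compound 3 (0.18 log units; within the scatter), so methoxy in place of hydrogen here gives no change that can be told from scatter. The second step concerns the other methoxy of compound 1, with hydrogen in place of methoxy, and reads an at least 1.6-fold lower number from compound 1 to compound 3 (0.22 log units; that floor lies within the scatter). Compound 1 stands at a limit of the assay and not at a number, so this step gives only a floor and its true size stays unknown: the limit of > 10000 nM in this assay, at which 1 of the 3 values shown sits.

As far as these compounds go, whether any group at the methoxy position can move the number beyond the scatter remains open. An amine, a carboxylic acid or a longer alkoxy chain in that place would bear on this.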